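Exchanging a side-chain ring on a shared core

The compounds below may be only part of what the source reports. "The series", "measured", "known", "first", "only" and "open" are said of these compounds alone.

Values so far in an ADME assay on MT4 cells (Homo sapiens) for cytotoxicity, read by MTT assay; on this read-out higher numbers stand for lower toxicity in this test and lower numbers for higher toxicity in this test
compound 1 `Cc1cc(C)cc(S(=O)(=O)c2c(C(=O)NCC(=O)NC(C)c3ccccc3)[nH]c3ccc(Cl)cc23)c1` gives 29400 nM
compound 2 `Cc1cc(C)cc(S(=O)(=O)c2c(C(=O)NCC(=O)NCCn3c(C)cnc3[N+](=O)[O-])[nH]c3ccc(Cl)cc23)c1` gives 24500 nM

Among the measured compounds shown here, compound 2 stands level, within the scatter, with the only other measured value. For the measured compounds named here, the one measured step is a 1.2-fold lower number from compound 1 to compound 2 (0.08 log units; within the scatter) and it put a five-membered aromatic ring with 2 hetero atoms in place of a six-membered aromatic ring of carbon only.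

Compound 3 `Cc1cc(C)cc(S(=O)(=O)c2c(C(=O)NCC(=O)NCc3ccccc3F)[nH]c3ccc(Cl)cc23)c1` has not been measured. Its structure differs by a group of 7 heavy atoms (6 carbon, 1 fluorine; one six-membered aromatic ring of carbon only) in place of a group of 10 heavy atoms (5 carbon, 3 nitrogen, 2 oxygen; one five-membered aromatic ring with 2 hetero atoms), on a saturated chain carbon bound to an amide-type nitrogen and so brings in 2-fluorophenyl, a six-membered aromatic ring of carbon only. This is close to the opposite ring exchange, though the two side chains are not identical. Going by the values given here, with a 1.2-fold lower number from compound 1 to compound 2 (0.08 log units; within the scatter) as the only guide, no step beyond the scatter is expected for compound 3 in this assay. The estimated step is a 1.1-fold higher number from compound 2 to compound 3 (0.04 log units; within the scatter) and no more than that is expected. Compound 3 is expected at 27000 nM, with an estimated range from 12000 nM to 60000 nM.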

Compound 3, half-maximal cytotoxic concentration: > 47300 nM
Compound 3 was reported as a limit (the forecaster's own chance of this, stated with the estimate: 10%); at least 1.7-fold (0.24 log units) between middle value and limit.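

In this assay the value of compound 3 is a limit and not a number: the limit of > 47300 nM in this assay, at which 1 of the 3 values shown sits. With 2-fluorophenyl in place of the five-membered aromatic ring with 2 hetero atoms, on a saturated chain carbon bound to an amide-type nitrogen, the result is an at least 1.9-fold higher number from compound 2 to compound 3 (0.28 log units; that floor lies within the scatter), while 2-fluorobenzyl in place of 1-phenylethyl gives an at least 1.6-fold higher number from compound 1 to compound 3 (0.20 log units; that floor lies within the scatter). Both floors lie within the scatter, so no change is established, but unlike the step from compound 1 to compound 2, these two steps have no upper bound and may be larger than printed.

From the compounds shown here alone, it remains open how far compound 3 lies past its limit and whether the fluorine contributes to the steps. Also open, going by these compounds, is how this read-out would respond to an amine or a carboxylic acid in place of the ring.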